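Adding a chloro to the shared core of compound 2

The compounds below may be only part of what the source reports. "The series", "measured", "known", "first", "only" and "open" are said of these compounds alone.

Measured compounds:
- compound 1 `Nc1nc(Cl)c2ncn(Cc3cccc(CCl)c3)c2n1`: 67600 nM
- compound 2 `ClCc1ccc(Cn2cnc3ncnc(Cl)c32)cc1`: 7070 nM
- compound 3 `ClCc1cccc(Cn2cnc3ncnc(Cl)c32)c1`: 47900 nM

These three compounds were tested in a functional assay on SF-268 cells (Homo sapiens) for cytotoxicity, read by sulforhodamine B assay, with a stated time of 48 h; on this read-out lower numbers stand for higher toxicity in this test and higher numbers for lower toxicity in this test. Of the three numbers, compound 2 has the lowest, and the gaps to compound 3 and to compound 1 both lie beyond the scatter, so compound 2 is the most toxic of the three in this assay.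

Compound 4 `ClCc1ccc(Cn2cnc3nc(Cl)nc(Cl)c32)cc1` has not been measured yet. It differs from compound 2 in one place: chloro in place of hydrogen on an aromatic carbon. Among the compounds with values here, no measured pair shows this exact change. Compound 1 and compound 3 carry different groups at the same spot of the shared core and give numbers that lie within the scatter of each other, which suggests that this spot tolerates change. A step of modest size is expected, with compound 4 somewhat more toxic than compound 2, so the estimated change is a 1.4-fold lower number from compound 2 to compound 4 (0.15 log units; within the scatter). Compound 4 is therefore expected to give about 5000 nM, likely between 1500 nM and 20000 nM.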

Compound 4, concentration lethal to 50% of the cells: 7940 nM
Compound 4: the middle estimate sits 1.6-fold (0.20 log units) below what was measured, and the stated range covers the measured number.
By their numbers in this assay, from the lowest: compounds 2 and 4 (each within the scatter of the next); then compounds 3 and 1 (each within the scatter of the next).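

In this assay, chloro in place of hydrogen on the aromatic carbon between two ring nitrogen atoms gives a 1.1-fold higher number from compound 2 to compound 4 (0.05 log units; within the scatter) and so leaves the number unchanged within the scatter. Within the data shown here, this is the first direct reading of this change at this position, as no earlier pair differed in one place. Nothing measured here gives a reason for this result.

This rests on a single pair of compounds. From the compounds shown here alone, how a methyl or a methoxy group at this position would read remains open.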